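A Nitro Group Added Where No Activity Has Yet Been Seen

A few compounds are considered here, and "the series" means these few. Any claim that something is new, unique, unknown or untested is made for them only; others in the source may bear on it.

The two measured compounds share one core, which compound 1 `COc1cc(-c2ncnn2-c2ccccc2)cc(OC)c1OC` carries with a plain phenyl ring. In a functional assay on HeLa cells (Homo sapiens) for antiproliferative activity, read by MTT assay, with a stated time of 72 h (a higher number here means a weaker inhibitor, a lower number a stronger inhibitor), compound 1 gives > 10000 nM, which is a limit of the assay and not a measured number. Compound 2 `COc1cc(-c2ncnn2-c2cccc([N+](=O)[O-])c2)cc(OC)c1OC` carries a nitro group in place of a hydrogen on that ring. In this assay compound 2 gives > 10000 nM, again a limit rather than a number. The step that the two limits leave unreadable from compound 1 to compound 2 cannot be read in size because of the limit of > 10000 nM in this assay, at which 2 of the 2 values shown sit.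

Compound 3 `COc1cc(-c2ncnn2-c2ccc([N+](=O)[O-])cc2)cc(OC)c1OC` differs from compound 1 by nitro in place of hydrogen on an aromatic carbon. Within the data shown here, the only measured step that bears on this change is the one from compound 1 to compound 2, and its size is not readable, so there is no measured guide for a direction. Compound 3 is therefore expected to give about 20000 nM in this assay, within a range from 7000 nM to 60000 nM, most likely again as a limit. That estimate means an expected step that the limit leaves unreadable from compound 1 to compound 3, no change beyond the scatter.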

Compound 3, half-maximal inhibitory concentration: > 10000 nM
Compound 3: no number, only a limit; the forecaster's own chance of this, stated with the estimate: 80%; the middle value does not contradict the limit.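

In this assay compound 3 gives > 10000 nM, which is a limit of the assay and not a number. The step from compound 1 to compound 3 cannot be read in size, and neither can any other step here, because the values offer only a shared limit: the limit of > 10000 nM in this assay, at which 3 of the 3 values shown sit. The compounds shown leave open whether any group on the phenyl ring of compound 1 can give a measured number in this assay.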